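A few compounds are considered here, and "the series" means these few. Any claim that something is new, unique, unknown or untested is made for them only; others in the source may bear on it.

Measured so far in an ADME assay on Vero cells (Chlorocebus sabaeus) for cytotoxicity, read by fluorescence; on this read-out higher numbers stand for weaker inhibition and lower numbers for stronger inhibition:
compound 1, `COC(=O)c1cc(-c2ccccc2)cc(OC)c1C`: 74000 nM
compound 2, `C/C(=C/[C@H](O)[C@H](O)c1ccccc1)CCO`: > 225000 nM
compound 3, `C/C(=C\c1ccccc1)[C@@H](O)C(C)(C)C(=O)O`: > 213000 nM

For compound 3 the value in this assay is a limit, not a number (the limit of > 213000 nM in this assay, at which 1 of the 3 values shown sits). For compound 2 the value in this assay is likewise a limit, not a number (the limit of > 225000 nM in this assay, at which 1 of the 3 values shown sits). Only compound 1 gives a number in this assay, so compound 3 stands at a limit with nothing to place it against.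

Compound 4, `C/C(=C\c1ccccc1)[C@@H](O)C(C)(C)O`, differs from compound 3 in one place: hydroxy in place of carboxy on a saturated chain carbon bound to three saturated chain carbons. Within the data shown here, no step between measured compounds exists to size this change. The step from compound 3 to compound 4 in this assay is expected to be an at least 1.0-fold lower number from compound 3 to compound 4 (0.02 log units; that floor lies within the scatter), nothing beyond the scatter. Compound 4 is therefore estimated at 200000 nM, within 90000 nM to 450000 nM, most likely reported again as a limit.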

Compound 4, half-maximal inhibitory concentration: > 242000 nM
Compound 4: a limit, no number (the forecaster's own chance of this, stated with the estimate: 70%); middle value at least 1.2-fold (0.08 log units) away from the limit.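

In this assay, compound 3 and compound 4 both stand at limits, not numbers, so no step can be read between them. The compounds shown leave open whether hydroxy in place of carboxy changes the value at all.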